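This account rests on a few compounds, and the source may have more. Where it says the series, first, only, none or still open, it means among the compounds named here.

Working notes on the series.

Compound 1 `C=C1C(=O)[C@]23C[C@@]1(O)CC[C@H]2c1ccc(O)c(C)c1[C@@H]3Cn1cc(-c2ccccn2)nn1` carries a pyridin-2-yl group on the triazole. In a functional assay on MCF7 cells (Homo sapiens) for cytotoxicity, read by MTT assay, with a stated time of 4 days (on this read-out higher numbers stand for weaker inhibition and lower numbers for stronger inhibition), compound 1 gives 2240 nM. Compound 3 `C=C1C(=O)[C@]23C[C@@]1(O)CC[C@H]2c1ccc(O)c(C)c1[C@@H]3Cn1cc(-c2ccc(C(F)(F)F)cc2)nn1` is the matched partner; in this assay compound 3 gives 1840 nM. The change between them is 4-(trifluoromethyl)phenyl in place of pyridin-2-yl on an aromatic carbon and the step is a 1.2-fold lower number from compound 1 to compound 3 (0.09 log units; within the scatter), so within this pair the exchange of the aryl group leaves the read-out essentially where it was.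

Compound 2 `Cc1c(O)ccc2c1[C@H](Cn1cc(-c3ccccn3)nn1)[C@@]13CC(=O)[C@@](C)(CC[C@@H]21)C3` keeps the pyridin-2-yl group but sits on a different core; how the core of compound 2 differs from the core of compound 1 is not broken down here. In this assay compound 2 gives > 20000 nM, which is a limit of the assay and not a number, as noted at the limit of > 20000 nM in this assay, at which 1 of the 3 values shown sits.

Compound 4 `Cc1c(O)ccc2c1[C@H](Cn1cc(-c3ccc(C(F)(F)F)cc3)nn1)[C@@]13CC(=O)[C@@](C)(CC[C@@H]21)C3` has not yet been measured. It stands to compound 2 as compound 3 stands to compound 1: the change is 4-(trifluoromethyl)phenyl in place of pyridin-2-yl on an aromatic carbon, the same change made at the same place. On the core of compound 1 that change produced a 1.2-fold lower number from compound 1 to compound 3 (0.09 log units; within the scatter), so the expected step from compound 2 to compound 4 is a step that the limit leaves unreadable from compound 2 to compound 4, resting on that single measured pair, and because compound 2 is known only as the limit > 20000 nM the outcome for compound 4 is most likely another limit. The estimate for compound 4 in this assay is 30000 nM, with a range from 12000 nM to 100000 nM.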

Compound 4, half-maximal inhibitory concentration: > 20000 nM
Compound 4: a limit, no number; the forecaster's own chance of this, stated with the estimate: 75%; the middle value does not contradict the limit.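

In this assay compound 4 gives > 20000 nM, which is a limit of the assay and not a number. Compound 2 sits at the same limit, so no step from compound 2 to compound 4 can be read: the limit of > 20000 nM in this assay, at which 2 of the 4 values shown sit.

The compounds shown leave open what 4-(trifluoromethyl)phenyl in place of pyridin-2-yl does on the core of compound 2.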